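Cyclopropyl for Ethyl at the Amine of Compound 2

This account rests on a few compounds, and the source may have more. Where it says the series, first, only, none or still open, it means among the compounds named here.

Measured so far in an assay on RBL-2H3 cells for displacement of a labelled ligand from adenosine receptor A3 (Rattus norvegicus), with a stated time of 60 min; a higher number here means a weaker inhibitor, a lower number a stronger inhibitor:
compound 1, `CCCCC#Cc1nc(NCc2cccc(Br)c2)c2ncn([C@H]3[C@H](O)[C@H](O)[C@@H]4C[C@@H]43)c2n1`, 59 nM
compound 2, `CCCCC#Cc1nc(NCC)c2ncn([C@H]3[C@H](O)[C@H](O)[C@@H]4C[C@@H]43)c2n1`, 176 nM
compound 3, `CCCCC#Cc1nc(NC)c2ncn([C@H]3[C@H](O)[C@H](O)[C@@H]4C[C@@H]43)c2n1`, 231 nM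

Compound 2 stands second highest of the three numbers: compound 3 lies within the scatter of it, while compound 1 sits lower, with a 3.0-fold higher number from compound 1 to compound 2 (0.47 log units; beyond the scatter). The step to compound 4, `CCCCC#Cc1nc(NC2CC2)c2ncn([C@H]3[C@H](O)[C@H](O)[C@@H]4C[C@@H]43)c2n1`, is cyclopropyl in place of ethyl on a nitrogen on an aromatic ring. Within the data shown here, two measured steps bear on it: a 1.3-fold higher number from compound 2 to compound 3 (0.12 log units; within the scatter) shows that removing the ethyl changes little, and a 3.0-fold higher number from compound 1 to compound 2 (0.47 log units; beyond the scatter) shows that only the far larger 3-bromophenyl shifts this assay beyond the scatter. Compound 4 is therefore expected to stay close to compound 2, as a 1.2-fold lower number from compound 2 to compound 4 (0.07 log units; within the scatter), with no change beyond the scatter. Compound 4 is estimated at 150 nM, between 70 nM and 320 nM.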

Compound 4, inhibition constant: 39 nM
Compound 4: the middle estimate sits 3.8-fold (0.59 log units) above what was measured; the measured number lies below the stated range.
By their numbers in this assay, from the lowest: compounds 4 and 1 (each within the scatter of the next); then compounds 2 and 3 (each within the scatter of the next).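

Cyclopropyl on this nitrogen moves the result in this assay beyond the scatter, with a 4.5-fold lower number from compound 2 to compound 4 (0.65 log units; beyond the scatter) and a 5.9-fold lower number from compound 3 to compound 4 (0.77 log units; beyond the scatter), whereas the change between methyl and ethyl had not done so. The 3-bromobenzyl group is therefore not the only substituent shown here to reach this range, and it cannot be told apart from cyclopropyl, with a 1.5-fold lower number from compound 1 to compound 4 (0.18 log units; within the scatter). Nothing available accounts for the shift. As far as these compounds go, it remains open whether isopropyl or cyclobutyl on the same nitrogen would give a similar number, and so whether the shift goes with the three-membered ring or with branching at the carbon bound to the nitrogen.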